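The compounds below may be only part of what the source reports. "The series", "measured", "known", "first", "only" and "open" are said of these compounds alone.

Working notes on the series. In a functional assay on A549 cells (Homo sapiens) for cytotoxicity, read by MTT assay, with a stated time of 48 h (a lower number here means a stronger inhibitor, a higher number a weaker inhibitor), compound 1 `COc1ccc(-c2c[nH]c(=O)n2-c2cc(OC)c(OC)c(OC)c2)cc1` gives > 50000 nM, which is a limit of the assay and not a number. Compound 2 `COc1ccc(-c2c[nH]c(=O)n2-c2cc(OC)c(OC)c(OC)c2)cc1[N+](=O)[O-]` gives > 50000 nM, also a limit. Both values therefore sit at the same limit: the limit of > 50000 nM in this assay, at which 2 of the 2 values shown sit. Compound 2 has no number, and no rank can be read for it.

The next change leads to compound 3 `COc1ccc(-c2c[nH]c(=O)n2-c2cc(OC)c(OC)c(OC)c2)cc1N`, with amino in place of nitro on an aromatic carbon, ortho to a methoxy group and meta to a large group: amino in place of nitro on an aromatic carbon.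

Going by the values given here, the only measured step, a step that the two limits leave unreadable from compound 1 to compound 2, has no readable size to carry forward, and no measured step covers this exchange. In this assay a readable change is expected only toward a stronger inhibitor, and a result that stays at the limit is about equally likely. That expectation rests on compound 2 at > 50000 nM, a limit.

The expected change is an at least 1.2-fold lower number from compound 2 to compound 3 (0.09 log units; that floor lies within the scatter), an estimate with little behind its size. For compound 3 the estimated value is 40000 nM, with an expected range from 5000 nM to 100000 nM.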

Compound 3, half-maximal inhibitory concentration: > 50000 nM
Compound 3: a limit, no number; the forecaster's own chance of this, stated with the estimate: 55%; middle value at least 1.2-fold (0.09 log units) away from the limit.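

In this assay compound 3 gives > 50000 nM, a limit and not a number. Going by these compounds alone, no step among compound 1, compound 2 and compound 3 can be read: the limit of > 50000 nM in this assay, at which 3 of the 3 values shown sit. The compounds shown leave open whether hydrogen, nitro and amino at this place differ at all in this assay, and none of them gives a number.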